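Longer Tail on the Shared Core: Cytotoxicity Toward Lung Cells

The source may report more compounds than this note shows. Statements on the series, on what has been measured and on what is new or still open speak of the compounds shown alone.

Measured compounds:
Compound 1, `CCCOC(=O)CCC(=O)N1CCN(CCCOc2cc3c(Nc4ccc(F)c(Cl)c4)ncnc3cc2OC)CC1`, gives 95.1% in a functional assay on A549 cells (Homo sapiens) for cytotoxicity, read by MTT assay, with a stated time of 24 h, tested at 10 uM; on this read-out higher numbers stand for a weaker effect at the one concentration tested and lower numbers for a stronger effect.
Compound 2, `CCCCCCCOC(=O)CCC(=O)N1CCN(CCCOc2cc3c(Nc4ccc(F)c(Cl)c4)ncnc3cc2OC)CC1`, gives 89.1% in this assay.
Compound 3, `CCCCCCCCCCCCCCOC(=O)CCC(=O)N1CCN(CCCOc2cc3c(Nc4ccc(F)c(Cl)c4)ncnc3cc2OC)CC1`, gives 100% in this assay.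

All three compounds share one core and differ only in how far a saturated tail reaches out from an oxygen next to a carbonyl group. Compound 3 holds the highest of the three numbers, yet its nearest neighbour lies within the scatter: a number 4.9 percentage points higher from compound 1 to compound 3 (within the scatter). Within the data shown here, only one step among the measured compounds passes the scatter, and it is modest: a number 10.9 percentage points higher from compound 2 to compound 3 (beyond the scatter). The third step runs the other way and stays within the scatter: a number 6 percentage points lower from compound 1 to compound 2 (within the scatter). Taken together, lengthening the tail has so far moved the read-out little, with no steady direction.

Compound 4, `CCCCCCCCCCCCCCCCCCCCOC(=O)CCC(=O)N1CCN(CCCOc2cc3c(Nc4ccc(F)c(Cl)c4)ncnc3cc2OC)CC1`, carries the same change once more: hexyl in place of hydrogen on a saturated chain carbon, ten or more bonds along the chain from an oxygen next to a carbonyl group. Because a number 4.9 percentage points higher from compound 1 to compound 3 (within the scatter) and a number 10.9 percentage points higher from compound 2 to compound 3 (beyond the scatter) are both small, the step of a number 3 percentage points lower from compound 3 to compound 4 (within the scatter) is expected to stay within the scatter. Compound 4 is therefore expected to give 97%, with a range from 85% to 106%.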

Compound 4, a percentage reported as activity, at one concentration (the size of the read-out at that concentration, not a potency): 94%
Beside the measured number, compound 4's estimate is 3 percentage points above it; the range from low to high includes it.
By their numbers in this assay, from the lowest: compounds 2, 4, 1 and 3 (each within the scatter of the next, the first and the last beyond it).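

Hexyl in place of hydrogen on a saturated chain carbon, along the chain from an oxygen next to a carbonyl group, gives the longest tail shown, and in this assay this change stays small (a number 6 percentage points lower from compound 3 to compound 4 (within the scatter)). Among these compounds, this far stretch of the chain thus takes a further hexyl without a step past the scatter, and the one modest step seen earlier (a number 10.9 percentage points higher from compound 2 to compound 3 (beyond the scatter)) does not carry on in the same direction. No measurement here offers an explanation for this result.

Every tail shown is a plain saturated chain, so it remains open whether an amine or a carboxylic acid at the end of the chain would move the read-out beyond the scatter. Going by these compounds, a phenyl ring in place of the tail remains an equally open case.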